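This account rests on a few compounds, and the source may have more. Where it says the series, first, only, none or still open, it means among the compounds named here.

Within the data shown here, compound 1 `O=c1cc(-c2ccccc2)oc2cc(OCCCCNc3nc4ccc(Cl)cc4s3)cc(O)c12` stands highest of the two numbers so far in a functional assay on SK-OV-3 cells (Homo sapiens) for cytotoxicity, read by sulforhodamine B assay, with a stated time of 48 h (a lower number here means a stronger inhibitor, a higher number a weaker inhibitor), giving 39.3 ug/mL; its nearest neighbour, compound 2 `O=c1cc(-c2ccccc2)oc2cc(OCCCCNc3nc4ccc(F)cc4s3)cc(O)c12`, gives 33.7 ug/mL. Among the measured compounds shown here, the only measured step between them, fluoro in place of chloro on an aromatic carbon, was a 1.2-fold lower number from compound 1 to compound 2 (0.07 log units; within the scatter), so a halogen exchange of this kind has so far produced nothing beyond the scatter. Compound 3 `O=c1cc(-c2ccccc2)oc2cc(OCCCCNc3nc4c(F)cc(F)cc4s3)cc(O)c12` carries 4,6-difluoro-1,3-benzothiazol-2-yl in place of 6-chloro-1,3-benzothiazol-2-yl on an amine nitrogen. For the measured compounds named here, the second fluoro has no precedent among the measured compounds, but nothing in the measured step points to a shift beyond the scatter, so none is expected in this assay. Compound 3 is estimated at 35 ug/mL, within 18 ug/mL to 70 ug/mL. The expected step is a 1.1-fold lower number from compound 1 to compound 3 (0.05 log units; within the scatter).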

Compound 3, half-maximal inhibitory concentration: 36.8 ug/mL
Compound 3: middle estimate off by 1.1-fold (0.02 log units), on the low side, and the stated range covers the measured number.
By their numbers in this assay, from the lowest: compounds 2, 3 and 1 (each within the scatter of the next).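

In this assay, 4,6-difluoro-1,3-benzothiazol-2-yl in place of 6-chloro-1,3-benzothiazol-2-yl on the amine nitrogen gives a 1.1-fold lower number from compound 1 to compound 3 (0.03 log units; within the scatter). Adding a further fluoro gives a 1.1-fold higher number from compound 2 to compound 3 (0.04 log units; within the scatter), so among these three compounds neither a second fluoro nor the loss of chloro moves the number beyond the scatter. No supporting measurement bears on this result.

Still open, as far as these compounds go, is whether a nitrile or methoxy on the aromatic ring, or a longer chain on the amine nitrogen, would produce a step beyond the scatter.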